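Trimming the Anilide: From Compound 1 to Compound 4

The source may hold more compounds than are shown below. What is called first, only, known or untested is meant among the compounds shown, and "the series" means these compounds.

Compound 1, `CC(C)(C)OC(=O)NCc1ccccc1NC(=O)c1cnc2ccccc2c1`, gives 15 ug/mL.
Compound 2, `NC(=O)c1ccccc1NC(=O)c1ccc2ccccc2n1`, gives 10 ug/mL.
Compound 3, `CC(C)(C)OC(=O)NCc1ccccc1NC(=O)c1cc2cc([N+](=O)[O-])ccc2o1`, gives 25 ug/mL.

All three numbers come from a physicochemical assay for solubility (on this read-out lower numbers stand for lower solubility and higher numbers for higher solubility), and they sit close together. Compound 1 holds the second highest of the three numbers; its nearest neighbour is compound 2 and its furthest is compound 3, and both of those gaps lie within the scatter of repeated measurements, so the three compounds cannot be separated by this assay.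

The unmeasured compound 4, `O=C(Nc1ccccc1)c1cnc2ccccc2c1`, differs from compound 1 in one place: hydrogen in place of ((tert-butoxycarbonyl)amino)methyl on an aromatic carbon. The amide-linked core is otherwise kept. Among the measured compounds shown here, no step between two measured compounds of this kind exists in the set, so the size of this step must be guessed from the cluster of values alone.

The expectation is a small step downward for compound 4 in this assay, one that may well not exceed the scatter. Compound 4 is thus expected to give 10 ug/mL, with a range from 3 ug/mL to 30 ug/mL. That estimate corresponds to an expected step of a 1.5-fold lower number from compound 1 to compound 4 (0.18 log units; within the scatter).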

Compound 4, solubility: 5 ug/mL
The estimate for compound 4 lay 2.0-fold (0.30 log units) above the measured number, and the stated range covers the measured number.
By their numbers in this assay, from the lowest: compounds 4, 2, 1 and 3 (each within the scatter of the next, the first and the last beyond it).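

In this assay, among the compounds shown here, replacing the ((tert-butoxycarbonyl)amino)methyl group on the aromatic carbon with hydrogen gives a 3.0-fold lower number from compound 1 to compound 4 (0.48 log units; beyond the scatter), the first step in this set that can be read across a single change. The earlier compounds shown here differed in more than one place and so could say nothing about this position, whereas this modest step shows that the read-out does respond to what the position carries, and that stripping the group back to hydrogen moves the number down rather than up. No measurement offered here accounts for the step, so the data give its size and direction but no explanation.

Because the whole group leaves at once, the step does not tell which part of it matters, and an aminomethyl group, a methyl group or a carboxylic acid at the same place would begin to divide the tert-butyl end, the carbamate and the methylene link from one another. On these data alone, it also remains open whether the same replacement would give a step of similar size on the other side of the amide found in compound 3.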